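From Phenyl to Methylamino on the Amide Nitrogen

The source may report more compounds than this note shows. Statements on the series, on what has been measured and on what is new or still open speak of the compounds shown alone.

Compound 1 `C[C@H]1O[C@H](CO)[C@@H](O)[C@H](O)[C@H]1O` gives 50100000 nM in an assay on isolated protein (Sus scrofa) for inhibition of glycogen phosphorylase, brain form (Homo sapiens); on this read-out lower numbers stand for stronger inhibition and higher numbers for weaker inhibition.
Compound 2 `O=C(Nc1ccccc1)[C@H]1O[C@H](CO)[C@@H](O)[C@H](O)[C@H]1O` gives 12600000 nM in this assay.

Going by the values given here, of these two numbers, compound 2 stands at the lower one; its only neighbour, compound 1, lies at a higher number, and that gap is beyond the scatter. Compound 3 `CNNC(=O)[C@H]1O[C@H](CO)[C@@H](O)[C@H](O)[C@H]1O` has not yet been measured. It differs from compound 2 by methylamino in place of phenyl on an amide-type nitrogen. Among the compounds with values here, no measured pair shows this kind of change, so the two known values say only that the amide-bearing compound 2 sits lower than compound 1, and nothing about what replacing the phenyl does. On that thin basis a small move toward weaker inhibition is expected, of a size that may not exceed the scatter: the step of a 2.4-fold higher number from compound 2 to compound 3 (0.38 log units; beyond the scatter) is the estimate. Compound 3 is accordingly expected to give 30000000 nM, with a range from 8000000 nM to 120000000 nM.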

Compound 3, inhibition constant: 2000000 nM
Beside the measured number, compound 3's estimate is 15-fold (1.18 log units) above it; measured number below the stated range.
By their numbers in this assay, from the lowest: compound 3; then compound 2; then compound 1.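

Swapping phenyl for methylamino on an amide-type nitrogen gives a 6.3-fold lower number from compound 2 to compound 3 (0.80 log units; beyond the scatter) in this assay, so at this position the aromatic ring is not required for the lower number, and the smaller group carrying a hydrogen-bond donor and acceptor does better. Set against the methyl on a saturated ring carbon, the whole (methylamino)carbamoyl group gives a 25-fold lower number from compound 1 to compound 3 (1.40 log units; beyond the scatter), a large step that exceeds anything the two earlier compounds showed. Nothing available here accounts for either step.

The compounds shown cannot separate the loss of phenyl from the gain of the methylamino nitrogen, since both happen in one step. A plain methyl, an unsubstituted amino group or an ethylamino chain on that same nitrogen would be needed to tell which part of the change matters, and how much of the methylamino group it takes.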